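The source may hold more compounds than are shown below. What is called first, only, known or untested is meant among the compounds shown, and "the series" means these compounds.

Measured so far:
compound 1 `Cn1cncc1CN1CC(N(CC2CCN(C(=O)c3ccco3)CC2)S(=O)(=O)c2ccccn2)Cc2cc(C#N)ccc21`: 0.5 10^-6 cm/s
compound 2 `Cn1cnc(S(=O)(=O)N(Cc2cccc(-n3cccc3)c2)C2Cc3cc(C#N)ccc3N(Cc3cncn3C)C2)c1`: 0.2 10^-6 cm/s

Both values come from an ADME assay on Caco-2 cells (Homo sapiens) for permeability, in the apical to basolateral direction; on this read-out higher numbers stand for higher permeability and lower numbers for lower permeability. Compound 1 holds the higher of the two numbers; compound 2 sits lower, and that gap lies beyond the scatter.

Compound 3 `Cn1cncc1CN1CC(N(CC2CCN(C(=O)c3cccs3)CC2)S(=O)(=O)c2ccccn2)Cc2cc(C#N)ccc21` differs from compound 1 in one place: thiophen-2-yl in place of furan-2-yl on a carbonyl carbon. Among the compounds with values here, no measured pair shows this change, so nothing here fixes its effect; in this assay the expected step is small, if anything slightly upward, and within the scatter. Compound 3 is therefore expected to give about 0.6 10^-6 cm/s, with a range from 0.3 10^-6 cm/s to 1.2 10^-6 cm/s. The expected step of a 1.2-fold higher number from compound 1 to compound 3 (0.08 log units; within the scatter) stays within the scatter.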

Compound 3, apparent permeability: 0.5 10^-6 cm/s
For compound 3 the middle estimate is 1.2-fold (0.08 log units) above the measured one, within the range that was stated.
By their numbers in this assay, from the lowest: compound 2; then compounds 1 and 3 (each within the scatter of the next).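

Placing thiophen-2-yl in place of furan-2-yl on a carbonyl carbon gives, in this assay, no change at the digits printed from compound 1 to compound 3 (within the scatter), the first direct reading of a single change at this position. Here, a ring sulfur and a ring oxygen give matching numbers in otherwise identical compounds. Nothing measured here accounts for this result. Going by these compounds, whether a phenyl ring, a simple amine or a longer carbon chain on this carbonyl would give a different number remains open. So does whether this exchange would read the same way on another core.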